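The source may report more compounds than this note shows. Statements on the series, on what has been measured and on what is new or still open speak of the compounds shown alone.

Measured compounds:
- compound 1 `CCC(=O)Nc1ccc(S(=O)(=O)Oc2ccccc2I)cc1`: 11000 nM
- compound 2 `CC(C)c1ccccc1OS(=O)(=O)c1ccc(NC(=O)NCCCCl)cc1`: 9300 nM

Both numbers come from a functional assay on M21 cells (Homo sapiens) for antiproliferative activity, read by sulforhodamine B assay, with a stated time of 48 h; on this read-out higher numbers stand for weaker inhibition and lower numbers for stronger inhibition. Compound 2 holds the lowest of the two numbers in this assay; its nearest neighbour is compound 1, whose number is higher by a margin that stays within the scatter, so the two values show no real separation between them. For the measured compounds named here, no step between measured compounds that differ in a single place is available here, and compound 1 and compound 2 differ from each other in two places at once, so their pair cannot isolate any one change.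

Compound 3 `O=C(NCCCCl)Nc1ccc(S(=O)(=O)Oc2ccccc2I)cc1` has not yet been measured. It differs from compound 2 in one place: iodo in place of isopropyl on an aromatic carbon. With both measured numbers lying so close together, nothing in the measured compounds points to iodo in place of isopropyl on an aromatic carbon shifting the result beyond the scatter in either direction. The step of a 1.1-fold lower number from compound 2 to compound 3 (0.04 log units; within the scatter) is therefore expected to be small, within the scatter. Compound 3 is estimated at 8500 nM, with a range from 3000 nM to 25000 nM.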

Compound 3, half-maximal inhibitory concentration: 4600 nM
Compound 3: middle estimate off by 1.8-fold (0.27 log units), on the high side; the measured number falls inside the stated range.
By their numbers in this assay, from the lowest: compound 3; then compounds 2 and 1 (each within the scatter of the next).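

In this assay, for the compounds shown here, iodo in place of isopropyl on an aromatic carbon, ortho to a large group, gives a 2.0-fold lower number from compound 2 to compound 3 (0.31 log units; beyond the scatter) and so provides the first reading of this position with the rest of the molecule held constant. With the 2-iodophenyl group kept, (3-chloropropyl)amino in place of ethyl on a carbonyl carbon gives a 2.4-fold lower number from compound 1 to compound 3 (0.38 log units; beyond the scatter) and shows that this second place also moves the number beyond the scatter, a shift that the close values of compound 1 and compound 2, which differ in both places, had left hidden. Nothing at hand explains either step, and each rests on a single pair of compounds.

The compounds shown leave open whether the lower number belongs to iodo alone or would also appear with bromo, chloro or methyl on the same aromatic carbon, and whether the 2-iodophenyl group would give a similar step with other groups on the carbonyl carbon. They also leave open how a longer chain, or an amine in place of the terminal chlorine, would read in this assay on this core.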